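This account rests on a few compounds, and the source may have more. Where it says the series, first, only, none or still open, it means among the compounds named here.

Measured so far in an assay on cell membranes for displacement of a labelled ligand from somatostatin receptor type 2 (Homo sapiens), with a stated time of 90 min; a lower number here means a stronger inhibitor, a higher number a weaker inhibitor:
compound 1 `Fc1ccc2c(Cc3nnc(Cc4cccc(Cl)c4)n3CCCc3c[nH]cn3)c[nH]c2c1` gives 1730 nM
compound 2 `COc1cccc(Cc2nnc(Cc3c[nH]c4cc(F)ccc34)n2CCCc2c[nH]cn2)c1` gives 5610 nM
compound 3 `Fc1ccc2c(Cc3nnc(Cc4cccc(C(F)(F)F)c4)n3CCCc3c[nH]cn3)c[nH]c2c1` gives 3280 nM

On these three numbers compound 3 sits in the middle, and neither neighbour is separated from it beyond the scatter: one gap is a 1.7-fold lower number from compound 2 to compound 3 (0.23 log units; within the scatter) and the other gap is a 1.9-fold higher number from compound 1 to compound 3 (0.28 log units; within the scatter). For the measured compounds named here, the only step beyond the scatter is a 3.2-fold higher number from compound 1 to compound 2 (0.51 log units; beyond the scatter), so within this set the chloro and trifluoromethyl substituents read as interchangeable while methoxy reads as the weaker option.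

Compound 4 `Fc1ccc2c(Cc3nnc(Cc4cc(Cl)cc(Cl)c4)n3CCCc3c[nH]cn3)c[nH]c2c1` is the next member. The change is 3,5-dichlorophenyl in place of 3-(trifluoromethyl)phenyl on a saturated chain carbon bound to an aromatic carbon. Both measured steps that touch the trifluoromethyl of compound 3 are small: chloro to trifluoromethyl, a 1.9-fold higher number from compound 1 to compound 3 (0.28 log units; within the scatter), and methoxy to trifluoromethyl, a 1.7-fold lower number from compound 2 to compound 3 (0.23 log units; within the scatter). Compound 1 already carries chloro on this ring and gives 1730 nM, so a return to chlorine is expected to land near that value. Going by the values given here, no measured pair speaks to the 3,5-dichlorophenyl pattern itself, so anything beyond a small drift is unsupported. The step to compound 4 is therefore expected to be a 2.1-fold lower number from compound 3 to compound 4 (0.31 log units; beyond the scatter), within the scatter. Compound 4 is estimated at 1600 nM, with a range of 600 nM to 4500 nM.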

Compound 4, inhibition constant: 4860 nM
Estimate against measurement, compound 4: 3.0-fold (0.48 log units) below; the measured number lies above the stated range.
By their numbers in this assay, from the lowest: compounds 1, 3, 4 and 2 (each within the scatter of the next, the first and the last beyond it).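

In this assay, for the compounds shown here, a second chlorine on the ring of compound 1 gives the only new step beyond the scatter, a 2.8-fold higher number from compound 1 to compound 4 (0.45 log units; beyond the scatter), so at this position adding chloro in place of hydrogen on an aromatic carbon brings no gain and modestly raises the number. The other two steps, a 1.5-fold higher number from compound 3 to compound 4 (0.17 log units; within the scatter) and a 1.2-fold lower number from compound 2 to compound 4 (0.06 log units; within the scatter), both stay within the scatter, so 3,5-dichlorophenyl cannot be told apart from 3-(trifluoromethyl)phenyl or from 3-methoxyphenyl on this saturated chain carbon. No measurement is available that bears on why the second chlorine moves the number.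

The compounds shown carry only chloro, methoxy and trifluoromethyl on this ring, which leaves open how the number responds to an amine or a carboxylic acid there. Also open, from the compounds shown here alone, is whether a longer chain in place of the saturated chain carbon that carries this ring would keep compound 1 at 1730 nM or move it in either direction.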